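Aryl swap on the piperazine dithiocarbamate series

A few compounds are considered here, and "the series" means these few. Any claim that something is new, unique, unknown or untested is made for them only; others in the source may bear on it.

Among the measured compounds shown here, compound 2 `Nc1nc(N)c2cc(CSC(=S)N3CCN(c4ccc(Cl)cc4)CC3)ccc2n1` gives 6990 nM in a functional assay on HeLa cells (Homo sapiens) for antiproliferative activity, read by MTT assay, with a stated time of 72 h (on this read-out lower numbers stand for stronger inhibition and higher numbers for weaker inhibition), the highest of the two numbers so far; compound 1 `COc1ccc(N2CCN(C(=S)SCc3ccc4nc(N)nc(N)c4c3)CC2)cc1` gives 1660 nM in this assay, and the step of a 4.2-fold higher number from compound 1 to compound 2 (0.62 log units; beyond the scatter) is the only one measured. Compound 3 `Nc1nc(N)c2cc(CSC(=S)N3CCN(c4ccccn4)CC3)ccc2n1` differs from compound 2 by pyridin-2-yl in place of 4-chlorophenyl on an amine nitrogen in a ring. For the measured compounds named here, no measured step touches a change of the whole ring, so that one step offers little guidance; a step within the scatter or a modest move is expected, direction open. Compound 3 is therefore estimated at 4000 nM in this assay (range 1200 nM to 13000 nM), an expected step of a 1.7-fold lower number from compound 2 to compound 3 (0.24 log units; within the scatter).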

Compound 3, half-maximal inhibitory concentration: 5090 nM
Compound 3: middle estimate off by 1.3-fold (0.10 log units), on the low side; the measured number falls inside the stated range.
By their numbers in this assay, from the lowest: compound 1; then compounds 3 and 2 (each within the scatter of the next).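

In this assay, pyridin-2-yl and 4-chlorophenyl on this amine nitrogen in a ring cannot be told apart (a 1.4-fold lower number from compound 2 to compound 3 (0.14 log units; within the scatter)), so exchanging the whole aromatic ring and gaining one hydrogen-bond acceptor leaves the number within the scatter. Set against 4-methoxyphenyl, however, pyridin-2-yl gives a modest step beyond the scatter (a 3.1-fold higher number from compound 1 to compound 3 (0.49 log units; beyond the scatter)), which leaves compound 1 apart from both other compounds. Nothing available explains either step.

Still open, from the compounds shown here alone, is whether the methoxy group itself carries this gap. Unsubstituted phenyl, or an ethoxy or amino group on the phenyl ring, would help separate that question.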